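From bromo to trifluoromethyl: a small expected step

The compounds below may be only part of what the source reports. "The series", "measured", "known", "first", "only" and "open" are said of these compounds alone.

- compound 1 `CCCCCCS(=O)(=O)c1ccc(O)c(C(=O)Nc2ccc(Br)cc2)c1` with 5.2
- compound 2 `CCCCS(=O)(=O)c1ccc(O)c(C(=O)Nc2ccc(Br)cc2)c1` with 5.2

In a physicochemical assay for acid dissociation, compound 2 gives 5.2 and stands level with compound 1 at the digits shown. Among the measured compounds shown here, the only measured step is no change at the digits printed from compound 1 to compound 2 (within the scatter) and it concerns hydrogen in place of ethyl on a saturated chain carbon, far from the bromo group. The next compound, compound 3 `CCCCS(=O)(=O)c1ccc(O)c(C(=O)Nc2ccc(C(F)(F)F)cc2)c1` carries one change, trifluoromethyl in place of bromo on an aromatic carbon which is trifluoromethyl in place of bromo on an aromatic carbon. For the measured compounds named here, no measured step touches that place, so the data give no direct size for this swap, and the flat step on the chain can only serve as weak guidance. The starting point is compound 2 at 5.2 and a small move toward the lower number is expected, though a result within the scatter would be no surprise. The estimated step is a number 0.10 log units lower from compound 2 to compound 3 (within the scatter) and it rests on judgement, not on a measured precedent. In this assay compound 3 is estimated at 5.1 with 4.8 to 5.3 as the expected range.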

Compound 3, acid dissociation constant: 6.2
The estimate for compound 3 lay 1.10 log units below the measured number; the whole stated range lies below it.
By their numbers in this assay, from the lowest: compounds 1 and 2 (each within the scatter of the next); then compound 3.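

In this assay, trifluoromethyl in place of bromo on an aromatic carbon gives a number 1.00 log units higher from compound 2 to compound 3 (beyond the scatter) and so shows that a swap at this place, para to a large group, can move the read-out clearly. Among the compounds shown here, with no change at the digits printed from compound 1 to compound 2 (within the scatter) on the saturated chain, the earlier compounds gave no measure of how far the number could move at this aromatic carbon, and the flat chain step turns out to say little about a change made here. No independent measurement is at hand that would account for the size of this step. 

A single swap at this place cannot show how the number follows the group placed there, so a nitrile, an amine or a carboxylic acid on the same aromatic carbon could land anywhere relative to bromo and trifluoromethyl. Going by these compounds, it also stays open whether trifluoromethyl in place of bromo gives a step of the same size when the longer chain of compound 1 is present on the sulfonyl group.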